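Replacing the formyl of compound 3 with pyridin-4-yl

This account rests on a few compounds, and the source may have more. Where it says the series, first, only, none or still open, it means among the compounds named here.

Three compounds share one core. Compound 1 `CC(=O)c1ccc2c(c1)C(n1ccccc1=O)=CC(C)(C)O2` gives 7.37 in a functional assay (aorta) with Rattus norvegicus as the target; a lower number here means a less potent compound, a higher number a more potent compound, by a factor of ten per unit of this negative logarithm. Compound 2 `CC1(C)C=C(n2ccccc2=O)c2cc(C(=O)c3ccc(O)cc3)ccc2O1` gives 6.65, and compound 3 `CC1(C)C=C(n2ccccc2=O)c2cc(C=O)ccc2O1` gives 6.91. The change from compound 1 to compound 2 brought a number 0.72 log units lower from compound 1 to compound 2 (beyond the scatter), and that from compound 1 to compound 3 brought a number 0.46 log units lower from compound 1 to compound 3 (beyond the scatter); between compound 2 and compound 3 the difference was a number 0.26 log units higher from compound 2 to compound 3 (within the scatter). Compound 3 thus holds the second highest of the three numbers, within the scatter of compound 2 and beyond it from compound 1.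

Compound 4 `CC1(C)C=C(n2ccccc2=O)c2cc(-c3ccncc3)ccc2O1` differs from compound 3 in one place: pyridin-4-yl in place of formyl on an aromatic carbon. Within the data shown here, no measured step makes this same change; the three known steps all vary the group on the carbonyl carbon and were modest or within the scatter. By analogy, the step from compound 3 to compound 4 is expected to be small, with no clear direction, at a number 0.01 log units lower from compound 3 to compound 4 (within the scatter). Compound 4 is therefore estimated at 6.9, between 6.2 and 7.6.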

Compound 4, logarithm of the reciprocal of the active concentration, log(1/C): 6.68
Beside the measured number, compound 4's estimate is 0.22 log units above it; measured number inside the range.
By their numbers in this assay, from the lowest: compounds 2, 4 and 3 (each within the scatter of the next); then compound 1.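

In this assay, among these compounds, this aromatic carbon also tolerates a group with no carbonyl at all: all the earlier compounds carried a carbonyl carbon there, while pyridin-4-yl in place of formyl gives a number 0.23 log units lower from compound 3 to compound 4 (within the scatter). Set against the (4-hydroxyphenyl)carbonyl group, pyridin-4-yl gives a number 0.03 log units higher from compound 2 to compound 4 (within the scatter), so a ring bonded straight to this position and a ring carried on a carbonyl are not told apart here. Among the compounds shown here, only acetyl stands clear of the new group, with a number 0.69 log units lower from compound 1 to compound 4 (beyond the scatter), which leaves acetyl as the one group at this position beyond the scatter of pyridin-4-yl.

Nothing at hand gives a reason for any of these steps. Open too, going by these compounds, is whether phenyl, pyridin-3-yl, an amine or a carboxylic acid on this aromatic carbon would reach the number of acetyl.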